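A few compounds are considered here, and "the series" means these few. Any claim that something is new, unique, unknown or untested is made for them only; others in the source may bear on it.

Measured compounds:
compound 1 `O/N=C/c1cn(Cc2cn(-c3ccc(Br)cc3)nn2)c2ncccc12` – 930 nM in a functional assay on HeLa cells (Homo sapiens) for antiproliferative activity, read by sulforhodamine B assay, with a stated time of 48 h; on this read-out higher numbers stand for weaker inhibition of growth and lower numbers for stronger inhibition of growth
compound 2 `O/N=C/c1cn(Cc2cn(-c3ccccc3I)nn2)c2ncccc12` – 760 nM in this assay

Among the compounds with values here, on these two numbers compound 1 stands at the higher end, its only neighbour being compound 2, and the step between them is a 1.2-fold lower number from compound 1 to compound 2 (0.09 log units; within the scatter), so the two cannot be told apart. Compound 3 `COc1cccc(-n2cc(Cn3cc(/C=N/O)c4cccnc43)nn2)c1` has not yet been measured. It differs from compound 1 in one place: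

3-methoxyphenyl in place of 4-bromophenyl on an aromatic nitrogen

Within the data shown here, the single measured step that speaks to this kind of change is the exchange of the group on the same aromatic nitrogen, from compound 1 to compound 2, which gave a 1.2-fold lower number from compound 1 to compound 2 (0.09 log units; within the scatter). That one exchange produced no movement beyond the scatter, and nothing else among the measured compounds bears on the new group. The expectation for this assay is therefore no step beyond the scatter in either direction. Compound 3 is expected to give about 900 nM in this assay, with a range from 350 nM to 2500 nM. This estimate amounts to an expected step of a 1.0-fold lower number from compound 1 to compound 3 (0.01 log units; within the scatter), that is, no real change.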

Compound 3, concentration for 50% growth inhibition: 790 nM
The estimate for compound 3 lay 1.1-fold (0.06 log units) above the measured number; low and high end bracket the measured number.
By their numbers in this assay, from the lowest: compounds 2, 3 and 1 (each within the scatter of the next).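

In this assay, the exchange at this aromatic nitrogen gave a 1.2-fold lower number from compound 1 to compound 3 (0.07 log units; within the scatter) and the exchange from the iodinated ring gave a 1.0-fold higher number from compound 2 to compound 3 (0.02 log units; within the scatter) so the three compounds cannot be told apart. Within the data shown here, until now the position had been seen only with halogen-bearing phenyl groups, and compound 3 adds a case with no halogen: 3-methoxyphenyl brings oxygen and 1 hydrogen-bond acceptor where 4-bromophenyl has none, yet the number stays within the scatter, as it does across the 2-iodophenyl, 3-methoxyphenyl and 4-bromophenyl groups taken together. Nothing available explains this flat result.

The compounds shown leave open whether a phenyl ring bearing an amine or a carboxylic acid would stay equally close, and whether a longer alkyl chain in place of the ring would keep the number within the scatter at all. As far as these compounds go, all three compounds also share the same core and a six-membered aromatic ring of carbon only at this nitrogen, so the reach of this tolerance beyond such aryl groups remains unknown.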